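The source may hold more compounds than are shown below. What is called first, only, known or untested is meant among the compounds shown, and "the series" means these compounds.

For the measured compounds named here, in an assay on CHO cells for agonist activity at Free fatty acid receptor 1 (Homo sapiens), read by calcium flux (on this read-out lower numbers stand for an effect already at smaller amounts and higher numbers for an effect only at larger amounts of compound), compound 2 `Cc1nc(-c2ccc(C(F)(F)F)cc2)sc1COc1ccc([C@H](CC(=O)O)c2nnnn2C)cc1` gives 41 nM, the lowest of the two numbers measured so far. Its nearest neighbour is compound 1 `Cc1nc(-c2ccc(C(F)(F)F)cc2)sc1COc1ccc([C@H](CC(=O)O)c2ncnn2C)cc1`, which in this assay gives 65 nM; the step of a 1.6-fold lower number from compound 1 to compound 2 (0.20 log units; within the scatter) lies within the scatter, so on these numbers the two compounds cannot be told apart. Compound 3 `Cc1nc(-c2ccc(C(F)(F)F)cc2)sc1COc1ccc([C@H](CC(=O)O)c2cnco2)cc1` has not yet been measured. It differs from compound 2 in one place: 1,3-oxazol-5-yl in place of 1-methyl-1H-tetrazol-5-yl on a saturated chain carbon bound to an aromatic carbon and a saturated chain carbon. Going by the values given here, the only measured step that bears on this change is the one from compound 1 to compound 2, which also exchanged the five-membered aromatic ring at this same place and stayed within the scatter. A second exchange of this ring is therefore expected to move the number in this assay only a little, perhaps slightly upward, by about a 2.2-fold higher number from compound 2 to compound 3 (0.34 log units; beyond the scatter). Compound 3 is thus estimated at 90 nM, with a range from 30 nM to 300 nM.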

Compound 3, half-maximal effective concentration: 57 nM
Estimate against measurement, compound 3: 1.6-fold (0.20 log units) above; the range from low to high includes it.
By their numbers in this assay, from the lowest: compounds 2, 3 and 1 (each within the scatter of the next).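

In this assay the step of a 1.4-fold higher number from compound 2 to compound 3 (0.14 log units; within the scatter) and the step of a 1.1-fold lower number from compound 1 to compound 3 (0.06 log units; within the scatter) both lie within the scatter, so the three compounds cannot be told apart on these numbers. The new information is that the ring on this saturated chain carbon can go from 1-methyl-1H-tetrazol-5-yl, with 4 hetero atoms and 4 hydrogen-bond acceptors, to 1,3-oxazol-5-yl, with 2 of each and no methyl group, and still give a number that cannot be separated from the others. No independent measurement is available to explain this result.

All three compounds carry a five-membered aromatic ring at this place. On these data alone, whether a number in the same range survives with a different kind of group there, such as a phenyl ring, an amine or a longer chain, remains open.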